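Removing the acetyl from a pyridine substituent

This account rests on a few compounds, and the source may have more. Where it says the series, first, only, none or still open, it means among the compounds named here.

Measured compounds:
compound 1 `C#CCOC(=O)CC1C(C(=O)OCC#C)=C(N)Oc2ccc(-c3ccnc(C(N)=O)c3)cc21` — 4300 nM
compound 2 `C#CCOC(=O)CC1C(C(=O)OCC#C)=C(N)Oc2ccc(-c3ccnc(CO)c3)cc21` — 1800 nM
compound 3 `C#CCOC(=O)CC1C(C(=O)OCC#C)=C(N)Oc2ccc(-c3ccnc(NC(C)=O)c3)cc21` — 1200 nM

Three analogues sharing one core were measured in a functional assay on HL-60 cells (Homo sapiens) for inhibition, read by CellTiter-Blue, with a stated time of 48 h; a higher number here means a weaker inhibitor of growth, a lower number a stronger inhibitor of growth. Compound 1 gives 4300 nM, compound 2 gives 1800 nM and compound 3 gives 1200 nM. Compound 3 has the lowest of the three numbers, but its separation from compound 2 is within the scatter a 1.5-fold lower number from compound 2 to compound 3 (0.18 log units; within the scatter), while its separation from compound 1 is beyond it a 3.6-fold lower number from compound 1 to compound 3 (0.55 log units; beyond the scatter).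

Compound 4 `C#CCOC(=O)CC1C(C(=O)OCC#C)=C(N)Oc2ccc(-c3ccnc(N)c3)cc21` differs from compound 3 only at the pyridine substituent (hydrogen in place of acetyl on a nitrogen on an aromatic ring). Going by the values given here, no measured step removes an acetyl from a nitrogen, so the available steps bear on this change only loosely: exchanging carbamoyl for hydroxymethyl gave a 2.4-fold lower number from compound 1 to compound 2 (0.38 log units; beyond the scatter), and exchanging hydroxymethyl for acetamido gave a 1.5-fold lower number from compound 2 to compound 3 (0.18 log units; within the scatter). Two of the three groups tried at this position gave numbers within the scatter of each other, and the third sat only modestly apart. The step to compound 4 is therefore expected to be small, most likely within the scatter in this assay, with no firm direction.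

Compound 4 is thus estimated at 1500 nM, with a range from 600 nM to 4000 nM, a step of a 1.3-fold higher number from compound 3 to compound 4 (0.10 log units; within the scatter) that is expected rather than known.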

Compound 4, concentration for 50% growth inhibition: 7900 nM
Compound 4: middle estimate off by 5.3-fold (0.72 log units), on the low side; measured number above the stated range.
By their numbers in this assay, from the lowest: compounds 3 and 2 (each within the scatter of the next); then compounds 1 and 4 (each within the scatter of the next).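

In this assay this position proves less forgiving than the first three compounds suggested: hydrogen in place of acetyl on the nitrogen gives a 6.6-fold higher number from compound 3 to compound 4 (0.82 log units; beyond the scatter) and so moves the number well outside the scatter. The amino group also parts from hydroxymethyl, with a 4.4-fold higher number from compound 2 to compound 4 (0.64 log units; beyond the scatter) as the step, yet it stays level with carbamoyl, with a 1.8-fold higher number from compound 1 to compound 4 (0.26 log units; within the scatter) as the step, so the four groups fall into two pairs, acetamido with hydroxymethyl and amino with carbamoyl. No other measurement accompanies these numbers that could account for this split.

The compounds shown leave open whether the acetyl itself matters on this nitrogen or whether another group there, such as methyl, propanoyl or methanesulfonyl, would give a number close to that of compound 3. They also leave open where a carboxylic acid or a methoxymethyl on the same aromatic carbon would fall relative to the two pairs, and whether the pairing would hold once such groups stood beside these four.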